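This account rests on a few compounds, and the source may have more. Where it says the series, first, only, none or still open, it means among the compounds named here.

Of the compounds shown here, two of a shared core have been measured in an assay on HEK293 cells for inhibition of Voltage-dependent T-type calcium channel subunit alpha-1H (Homo sapiens), read by patch clamp, using a membrane potential dye; a lower number here means a stronger inhibitor, a higher number a weaker inhibitor. Compound 1 `CN1C(=O)C2(CCN(C(=O)Nc3cc(F)cc(F)c3)CC2)C1c1ccc(Cl)cc1` gives 920 nM in this assay. Compound 2 `CC[C@H](C)[C@H](NC(=O)N1CCC2(CC1)C(=O)N(c1cccc(F)c1)C2c1ccc(Cl)cc1)C(=O)NC` gives 182 nM, the lower of the two numbers, and its gap to compound 1 lies beyond the usual scatter. Compound 3 `COC(=O)[C@H](CO)NC(=O)N1CCC2(CC1)C(=O)N(c1cccc(F)c1)C2c1ccc(Cl)cc1` carries 2-hydroxy-1-(methoxycarbonyl)ethyl in place of 2-methyl-1-(methylcarbamoyl)butyl on an amide-type nitrogen. Among the measured compounds shown here, no measured pair shows this exact change, so the expected step from compound 2 to compound 3 is estimated as a modest loss, a 2.7-fold higher number from compound 2 to compound 3 (0.44 log units; beyond the scatter), since the smaller, more oxygen-rich group replaces a larger branched one. Compound 3 is thus expected at 500 nM, between 200 nM and 1300 nM.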

Compound 3, half-maximal inhibitory concentration: 3330 nM
Estimate against measurement, compound 3: 6.7-fold (0.82 log units) below; measured number outside the range, above it.
By their numbers in this assay, from the lowest: compound 2; then compound 1; then compound 3.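

Swapping 2-methyl-1-(methylcarbamoyl)butyl for 2-hydroxy-1-(methoxycarbonyl)ethyl on the amide-type nitrogen gives an 18-fold higher number from compound 2 to compound 3 (1.26 log units; beyond the scatter) in this assay and provides the first change at a single place among these compounds. It shows that the number is highly sensitive to the group at this position. The two groups differ in several ways at once, including atom types and stereocentres, so this step cannot assign the loss to any one part.

On these data alone, whether a carboxylic acid or a longer chain here would give a number nearer that of compound 2 or compound 3 remains open. No measurement shown explains the size of this step.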